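Swapping the aryl group: a fluoromethylphenyl gives way to fluorophenyl

This account rests on a few compounds, and the source may have more. Where it says the series, first, only, none or still open, it means among the compounds named here.

Three compounds built on one shared core differ only in the aryl group attached to it. Compound 1 `COc1cccc(-c2ccc3ncn(-c4cc(OC)c(OC)c(OC)c4)c3c2)c1` gives 3310 nM in a functional assay on SGC-7901 cells (Homo sapiens) for antiproliferative activity, read by MTT assay, with a stated time of 72 h; on this read-out higher numbers stand for weaker inhibition and lower numbers for stronger inhibition. Compound 2 `COc1cc(-n2cnc3ccc(-c4cccc(C)c4C)cc32)cc(OC)c1OC` gives 3040 nM in this assay, and compound 3 `COc1cc(-n2cnc3ccc(-c4ccc(C)cc4F)cc32)cc(OC)c1OC` gives 5650 nM in this assay. Compound 3 carries the highest of these three numbers, yet the steps of a 1.7-fold higher number from compound 1 to compound 3 (0.23 log units; within the scatter) and a 1.9-fold higher number from compound 2 to compound 3 (0.27 log units; within the scatter) both sit inside the scatter, as does a 1.1-fold lower number from compound 1 to compound 2 (0.04 log units; within the scatter), so the three cannot be placed in any order.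

Compound 4 `COc1cc(-n2cnc3ccc(-c4ccc(F)cc4)cc32)cc(OC)c1OC` differs from compound 3 in one place: 4-fluorophenyl in place of 2-fluoro-4-methylphenyl on an aromatic carbon. Going by the values given here, the steps that bear on this change are the three already described, each of which replaced the same aryl group and none of which moved the number beyond the scatter. On that basis no step beyond the scatter is expected in this assay for the change from compound 3 to compound 4, and the step of a 1.3-fold lower number from compound 3 to compound 4 (0.10 log units; within the scatter) is expected to be small. Compound 4 is therefore estimated at 4500 nM in this assay, with a range from 1500 nM to 14000 nM.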

Compound 4, half-maximal inhibitory concentration: 3500 nM
For compound 4 the middle estimate is 1.3-fold (0.11 log units) above the measured one; measured number inside the range.
By their numbers in this assay, from the lowest: compounds 2, 1, 4 and 3 (each within the scatter of the next).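

In this assay, going by these compounds alone, the exchange of 2-fluoro-4-methylphenyl for 4-fluorophenyl gives a 1.6-fold lower number from compound 3 to compound 4 (0.21 log units; within the scatter) and the exchanges from the other two aryl groups give a 1.2-fold higher number from compound 2 to compound 4 (0.06 log units; within the scatter) and a 1.1-fold higher number from compound 1 to compound 4 (0.02 log units; within the scatter) with no step leaving the scatter. The result adds an aryl group that carries fluorine but no methyl, and the four compounds at this position still cannot be told apart in this assay. No other measurement is available that bears on this result.

As far as these compounds go, all four groups at this position are substituted phenyl rings, so it stays open whether an amine, a carboxylic acid or a morpholine ring there would move the number beyond the scatter. The compounds shown also leave open whether changes elsewhere on the shared core, such as to its three methoxy groups, would matter more than this aryl group.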